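The source may report more compounds than this note shows. Statements on the series, on what has been measured and on what is new or still open speak of the compounds shown alone.

Measured compounds:
Compound 1, `COc1ccc(CNc2nc(-c3ccccc3C(F)(F)F)nc3ccccc23)cc1`: in an assay on a protein complex for inhibition of ubiquitin carboxyl-terminal hydrolase 1/WD repeat-containing protein 48 (Homo sapiens), read by fluorescence (on this read-out lower numbers stand for stronger inhibition and higher numbers for weaker inhibition), compound 1 gives 6200 nM.
Compound 2, `FC(F)(F)c1ccccc1-c1nc(NCc2ccc(-c3ccccc3)cc2)c2ccccc2n1`: in this assay compound 2 gives 3700 nM.

Among the measured compounds shown here, compound 2 carries the lower of the two numbers, but its only neighbour is compound 1, and the step of a 1.7-fold lower number from compound 1 to compound 2 (0.22 log units; within the scatter) lies within the scatter, so no order between compound 1 and compound 2 can be claimed.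

Compound 3, `FC(F)(F)c1cc(-c2ccc(CNc3nc(-c4ccccc4C(F)(F)F)nc4ccccc34)cc2)ccn1`, differs from compound 2 by 2-(trifluoromethyl)pyridin-4-yl in place of phenyl on an aromatic carbon. For the measured compounds named here, the single measured step, a 1.7-fold lower number from compound 1 to compound 2 (0.22 log units; within the scatter), concerns a different replacement at that aromatic carbon and was itself within the scatter, so it offers no guide to what the new group does. With nothing further to rest on, the change is expected to give no step beyond the scatter in this assay. The estimate for compound 3 is therefore 3000 nM, with a range of 1000 nM to 9000 nM. This expected estimate corresponds to a 1.2-fold lower number from compound 2 to compound 3 (0.09 log units; within the scatter).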

Compound 3, half-maximal inhibitory concentration: 4900 nM
Compound 3: middle estimate off by 1.6-fold (0.21 log units), on the low side; measured number inside the range.
By their numbers in this assay, from the lowest: compounds 2, 3 and 1 (each within the scatter of the next).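

At the aromatic carbon para to a large group, the 2-(trifluoromethyl)pyridin-4-yl group gives a 1.3-fold higher number from compound 2 to compound 3 (0.12 log units; within the scatter) in this assay when it replaces phenyl and a 1.3-fold lower number from compound 1 to compound 3 (0.10 log units; within the scatter) when it replaces methoxy. The position therefore now holds three different groups, including one with a ring nitrogen and a trifluoromethyl group, and none of the steps between them goes beyond the scatter, so no order among the three can be drawn. Nothing at hand accounts for this flat result.

Still open, as far as these compounds go, is whether a different kind of group at this carbon, such as a primary amine, a carboxylic acid or a longer alkyl chain, would give a step beyond the scatter. Also open, from the compounds shown here alone, is whether replacing the trifluoromethyl group on the other phenyl ring would do so.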